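The compounds below may be only part of what the source reports. "The series", "measured", "known", "first", "only" and "open" are said of these compounds alone.

Measured so far in a functional assay on BMDM cells (Mus musculus, strain C57BL/6) for inhibition, with a stated time of 2 days; a lower number here means a stronger inhibitor, a higher number a weaker inhibitor:

- compound 1 `COc1ccc(-c2cn(CC(=O)Nc3nc4ccccc4s3)nn2)cc1`: 1330 nM
- compound 3 `Cc1csc(NC(=O)Cn2cc(-c3cccs3)nn2)n1`: 40 nM
- compound 2 `COc1cccc(-c2cn(-c3ccc(C(F)(F)F)cc3)nc2C(=O)NC2CCCCC2)c1`: the value > 30000 nM is a limit of the assay, not a number

Compound 1 holds the highest of the two numbers shown in this assay, and so is the weaker inhibitor of the two; compound 3 sits far below it, beyond the usual scatter. For compound 2 the assay reports only a limit (the limit of > 30000 nM in this assay, at which 1 of the 3 values shown sits).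

The next compound, compound 4 `O=C(Cn1cc(-c2cccs2)nn1)Nc1nc2ccccc2s1`, is compound 1 with one change: thiophen-2-yl in place of 4-methoxyphenyl on an aromatic carbon. The same thiophen-2-yl group on the same kind of ring is found in compound 3, which gives 40 nM in this assay. On that basis, a clear decrease in the number is expected from compound 1 to compound 4, a step estimated at a 6.7-fold lower number from compound 1 to compound 4 (0.82 log units; beyond the scatter). For compound 4 the expected value in this assay is therefore 200 nM, with a likely range from 60 nM to 700 nM.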

Compound 4, half-maximal inhibitory concentration: 21400 nM
Estimate against measurement, compound 4: 110-fold (2.03 log units) below, outside the stated range (above it).
By their numbers in this assay, from the lowest: compound 3; then compound 1; then compound 4. At a limit, above all of these: compound 2.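

In this assay the aromatic carbon of the five-membered ring with 3 nitrogen proves sensitive to what it carries: putting thiophen-2-yl in place of 4-methoxyphenyl gives a 16-fold higher number from compound 1 to compound 4 (1.21 log units; beyond the scatter), so on this core 4-methoxyphenyl is the better of the two. Thiophen-2-yl therefore does not give a low number by itself: compound 3 carries it at 40 nM, while compound 4 carries it at 21400 nM, so its worth depends on the rest of the molecule. The data shown give no cause for this step.

From the compounds shown here alone, whether 4-methoxyphenyl would also beat thiophen-2-yl on the core of compound 3 stays open. So does the outcome at this carbon with other groups, such as an unsubstituted phenyl, a pyridine or an amine.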